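A few compounds are considered here, and "the series" means these few. Any claim that something is new, unique, unknown or untested is made for them only; others in the source may bear on it.

Measured compounds in a functional assay on SW-620 cells (Homo sapiens) for cytotoxicity, read by MTT assay, with a stated time of 72 h; a higher number here means a weaker inhibitor, a lower number a stronger inhibitor:
compound 1 `COc1ccc(/C=C2\CCC/C(=C\c3ccc(Cl)cc3)C2=O)cc1OC` — 5900 nM
compound 2 `COc1cccc(/C=C2\CCC/C(=C\c3ccc(OC)c(OC)c3)C2=O)c1` — 3700 nM

Compound 2 holds the lower of the two numbers, but the step of a 1.6-fold lower number from compound 1 to compound 2 (0.20 log units; within the scatter) lies within the scatter, so the two compounds are not told apart. Compound 3 `COc1ccc(/C=C2\CCC/C(=C\c3ccc(O)c(Cl)c3)C2=O)cc1OC` differs from compound 2 in one place: 3-chloro-4-hydroxyphenyl in place of 3-methoxyphenyl on a double-bonded chain carbon bound to a double-bonded ring carbon. Among the compounds with values here, the only measured step, a 1.6-fold lower number from compound 1 to compound 2 (0.20 log units; within the scatter), also exchanged one aryl group for another and stayed within the scatter; no measured pair carries the 3-chloro-4-hydroxyphenyl group, so the data give no direction. Accordingly the step of a 1.1-fold higher number from compound 2 to compound 3 (0.03 log units; within the scatter) is expected to stay within the scatter in this assay. For compound 3 the estimated value is 4000 nM, ranging from 1500 nM to 12000 nM.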

Compound 3, half-maximal inhibitory concentration: 7100 nM
Compound 3: the middle estimate sits 1.8-fold (0.25 log units) below what was measured, within the range that was stated.
By their numbers in this assay, from the lowest: compounds 2, 1 and 3 (each within the scatter of the next).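

In this assay, a 3-chloro-4-hydroxyphenyl group on a double-bonded chain carbon bound to a double-bonded ring carbon stays within the scatter of both 3-methoxyphenyl (a 1.9-fold higher number from compound 2 to compound 3 (0.28 log units; within the scatter)) and 4-chlorophenyl (a 1.2-fold higher number from compound 1 to compound 3 (0.08 log units; within the scatter)). The three aryl groups shown at this position, including one with a hydrogen-bond donor, are therefore not told apart. No evidence is available to explain this result. On these data alone, whether an aminophenyl or carboxyphenyl group at this position would give a step beyond the scatter remains open.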